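Carbonyl substituent swap from compound 2 to compound 3

The source may hold more compounds than are shown below. What is called first, only, known or untested is meant among the compounds shown, and "the series" means these compounds.

In a functional assay on HepG2 cells (Homo sapiens), read by MTT assay, with a stated time of 48 h (on this read-out lower numbers stand for stronger inhibition and higher numbers for weaker inhibition), compound 1 `CCN(CC)CCCNC(=O)c1ccc(C(CC)(CC)c2ccc(OCC(=O)C(C)(C)C)c(C)c2)n1CC` gives 180 nM, and compound 2 `CCN(CC)CCCNC(=O)c1ccc(C(CC)(CC)c2ccc(OCC(O)C(C)(C)C)c(C)c2)n1CC` gives 1100 nM. For the measured compounds named here, compound 2 thus holds the higher of the two numbers so far. Compound 3 `C=CCN(C)C(=O)c1ccc(C(CC)(CC)c2ccc(OCC(O)C(C)(C)C)c(C)c2)n1CC` keeps the 1-hydroxy-2,2-dimethylpropyl group of compound 2 and differs at another place: allyl(methyl)amino in place of (3-(diethylamino)propyl)amino on a carbonyl carbon. Allyl(methyl)amino stands in place of (3-(diethylamino)propyl)amino on a carbonyl carbon.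

Going by the values given here, only one measured step is available, a 6.1-fold higher number from compound 1 to compound 2 (0.79 log units; beyond the scatter), and it concerns the exchange of (tert-butyl)carbonyl for 1-hydroxy-2,2-dimethylpropyl, not the group on the carbonyl carbon. Among the compounds with values here, no measured pair varies that group, so the data give no direct reading of this change. That step serves only as a scale for what one change can do in this series. The present exchange is a large one, so a step of at least similar size is expected, towards a higher number, with the direction a judgement and not a measured trend. The expected shift is a 2.3-fold higher number from compound 2 to compound 3 (0.36 log units; beyond the scatter) in this assay. Compound 3 is estimated at 2500 nM, within a range of 600 nM to 10000 nM.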

Compound 3, half-maximal inhibitory concentration: > 50000 nM
Compound 3 was reported as a limit (the forecaster's own chance of this, stated with the estimate: 15%); middle value at least 20-fold (1.30 log units) from the limit.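

For the compounds shown here, the group on the carbonyl carbon proves to matter in this assay, and more than the earlier change on the oxygen-bearing chain: allyl(methyl)amino in place of (3-(diethylamino)propyl)amino gives an at least 45-fold higher number from compound 2 to compound 3 (1.65 log units; beyond the scatter), whereas the only earlier step was a 6.1-fold higher number from compound 1 to compound 2 (0.79 log units; beyond the scatter). This exchange removes the diethylamino chain end and the amide hydrogen together, and the loss of inhibition cannot be assigned to either one from this single pair. The result for compound 3 is a limit of the assay and not a number: the limit of > 50000 nM in this assay, at which 1 of the 3 values shown sits.

From the compounds shown here alone, it remains open whether the chain end with its amine, the amide hydrogen, or both are needed for the activity seen with compound 2; a (3-(diethylamino)propyl)(methyl)amino group or a plain allylamino group on the same carbonyl carbon would separate these two parts of the change. Going by these compounds, it is also open whether a shorter chain ending in a dimethylamino group would hold the number near that of compound 2, and whether the (tert-butyl)carbonyl group of compound 1 would alter the outcome with allyl(methyl)amino in place.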